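Butyl to cyclohexyl and tolerated concentration in one series

This account rests on a few compounds, and the source may have more. Where it says the series, first, only, none or still open, it means among the compounds named here.

Measured so far, in an ADME assay on HepG2 cells (Homo sapiens) for cytotoxicity, read by CellTiter-Glo, with a stated time of 48 h; a higher number here means that more compound is tolerated, a lower number that less compound is tolerated:
compound 1, `CCCCNc1nc2ccc(OC)cc2nc1S(C)(=O)=O`: 20000 nM
compound 2, `COc1ccc2nc(NC3CCCCC3)c(S(C)(=O)=O)nc2c1`: 12600 nM
compound 3, `CCCCNc1nc2cc(Cl)ccc2nc1S(C)(=O)=O`: 6310 nM

Compound 1 and compound 2 share a core and differ by cyclohexyl in place of butyl on a nitrogen on an aromatic ring; that change gave a 1.6-fold lower number from compound 1 to compound 2 (0.20 log units; within the scatter). Compound 3 carries a different core; how the two cores differ is not broken down here. In this assay compound 3 stands lowest of the three, though its gap to compound 2 is within the scatter and only its gap to compound 1 lies beyond it.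

Compound 4, `CS(=O)(=O)c1nc2ccc(Cl)cc2nc1NC1CCCCC1`, awaits this assay. It differs from compound 3 by cyclohexyl in place of butyl on a nitrogen on an aromatic ring, the same change as between compound 1 and compound 2. Because that earlier change gave a 1.6-fold lower number from compound 1 to compound 2 (0.20 log units; within the scatter), a similar, small step is expected here, a 1.6-fold lower number from compound 3 to compound 4 (0.20 log units; within the scatter), resting on a single precedent only. The estimate for compound 4 is 4000 nM, between 1500 nM and 11000 nM.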

Compound 4, half-maximal cytotoxic concentration: 5010 nM
The estimate for compound 4 lay 1.3-fold (0.10 log units) below the measured number; the range from low to high includes it.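

Cyclohexyl in place of butyl gives a 1.3-fold lower number from compound 3 to compound 4 (0.10 log units; within the scatter) in this assay. Set beside the earlier step, this shows that the change carries from one core to the other with no difference that can be told from noise: the same change on two cores in this assay, a 1.6-fold lower number (0.20 log units; within the scatter) from compound 1 to compound 2 and a 1.3-fold lower number (0.10 log units; within the scatter) from compound 3 to compound 4, 1.3-fold (0.10 log units) apart, within the scatter of two such steps

It does not show that the change itself has a real effect on either core, since each step lies within the scatter, and two cores are too few to support a rule for the series.

Open, on these data alone, is whether a longer chain, a phenyl ring or a carboxylic acid on that nitrogen would move the number beyond the scatter. Also open, as far as these compounds go, is whether the small step holds on any further core.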